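The compounds below may be only part of what the source reports. "The series", "measured", "known", "first", "only" and "open" are said of these compounds alone.

Compound 1, `COc1cc(OC)c2c(=O)cc(C3(O)C=CC(=O)C=C3)oc2c1`, is measured in a functional assay on Hep 3B2 cells (Homo sapiens) for cytotoxicity, read by colorimetric assay and MTT assay, with a stated time of 72 h (on this read-out lower numbers stand for stronger inhibition and higher numbers for weaker inhibition), and gives 670 nM. Compound 2, `COc1cc(OC)c2c(=O)cc(C3(OC)C=CC(=O)C=C3)oc2c1`, carries the change methyl in place of hydrogen on an oxygen on a saturated carbon and in this assay gives 3780 nM, so that the step of a 5.6-fold higher number from compound 1 to compound 2 (0.75 log units; beyond the scatter) is a clear weakening of the effect. Compound 3, `O=C1C=CC(O)(c2cc(=O)c3c(O)cccc3o2)C=C1`, belongs to a different core; how the core of compound 3 differs from that of compound 1 is not broken down here. In this assay compound 3 gives 1300 nM, a number that lies within the usual scatter of the number of compound 1 and below the number of compound 2. Compound 4, `COC1(c2cc(=O)c3c(O)cccc3o2)C=CC(=O)C=C1`, is not yet measured; it differs from compound 3 by methyl in place of hydrogen on an oxygen on a saturated carbon, the same change, at the same place, as that from compound 1 to compound 2. Among the compounds with values here, on the strength of the one measured instance, a 5.6-fold higher number from compound 1 to compound 2 (0.75 log units; beyond the scatter), the step is expected to be of similar size, a 5.0-fold higher number from compound 3 to compound 4 (0.70 log units; beyond the scatter). Compound 4 is therefore estimated at 6500 nM in this assay, with a range from 2500 nM to 18000 nM.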

Compound 4, half-maximal inhibitory concentration: 2320 nM
The estimate for compound 4 lay 2.8-fold (0.45 log units) above the measured number; measured number outside the range, below it.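

In this assay the change from hydroxy to methoxy gives a 1.8-fold higher number from compound 3 to compound 4 (0.25 log units; within the scatter), so on this second core the step cannot be told apart from the usual scatter. The change therefore does not carry over at the same size from one core to the other: the same change on two cores in this assay, a 5.6-fold higher number (0.75 log units; beyond the scatter) from compound 1 to compound 2 and a 1.8-fold higher number (0.25 log units; within the scatter) from compound 3 to compound 4, 3.2-fold (0.50 log units) apart, beyond the scatter of two such steps. This shows that a step read on one core in this series is not a safe guide to its size on the other, but two pairs give no rule for further cores and do not show which part of the cores goes with the gap.

All four compounds carry either hydroxy or methoxy on this saturated carbon, which leaves open how a longer chain on the oxygen, such as ethoxy, or an amine in place of the oxygen would read in this assay. Also open, from the compounds shown here alone, is whether the same change would give a step nearer the larger or the smaller one on a core carrying a carboxylic acid.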